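The source may hold more compounds than are shown below. What is called first, only, known or untested is meant among the compounds shown, and "the series" means these compounds.

Measured so far:
- compound 1, `COc1ccc(C(=O)c2cc(OC)c(OC)c(OC)c2)cc1NC(=O)/C=C/c1cc(OC)c(OC)c(OC)c1`: 1500 nM
- compound 2, `COc1ccc(/C=C/C(=O)Nc2cc(C(=O)c3cc(OC)c(OC)c(OC)c3)cc(OC)c2OC)cc1`: 11200 nM

Both compounds were tested in a functional assay on HeLa cells (Homo sapiens) for cytotoxicity, read by MTT assay, with a stated time of 72 h; a higher number here means a weaker inhibitor, a lower number a stronger inhibitor. Compound 1 gives 1500 nM, while compound 2 gives 11200 nM, the higher of the two numbers and beyond the usual scatter from compound 1. The two compounds share a core and differ in the aryl group at the end of the unsaturated amide chain, but no single-point comparison between them has been recorded.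

Compound 3, `COc1cc(C(=O)c2cc(OC)c(OC)c(OC)c2)cc(NC(=O)/C=C/c2cc(F)c(F)c(F)c2)c1OC`, has not yet been measured. It keeps the core of compound 2 and changes only the group on the unsaturated chain: 3,4,5-trifluorophenyl in place of 4-methoxyphenyl on a double-bonded chain carbon bound to a double-bonded chain carbon. Nothing in the two measured compounds shows how a trifluorophenyl group behaves here, so the step is expected to be modest, from compound 2 to compound 3 estimated as a 1.4-fold lower number from compound 2 to compound 3 (0.15 log units; within the scatter), within the scatter or a little toward a lower number. For compound 3 the expected value in this assay is 8000 nM, with a range from 2000 nM to 30000 nM.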

Compound 3, half-maximal inhibitory concentration: 5000 nM
Beside the measured number, compound 3's estimate is 1.6-fold (0.20 log units) above it; low and high end bracket the measured number.
By their numbers in this assay, from the lowest: compound 1; then compound 3; then compound 2.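

In this assay, putting 3,4,5-trifluorophenyl in place of 4-methoxyphenyl on a double-bonded chain carbon bound to a double-bonded chain carbon gives a 2.2-fold lower number from compound 2 to compound 3 (0.35 log units; beyond the scatter) and this modest step lies beyond the scatter. It is the only single-place comparison shown, and it establishes that the number responds to the aryl group at this position, moving lower when a ring with one hydrogen-bond acceptor gives way to a ring with none. No measurement at hand says why the number moved.

A single swap removes the methoxy group and adds three fluorine atoms together, leaving open which of these changes matters. On these data alone, a plain phenyl group or a chlorine-bearing phenyl ring at the same place could help separate them, and the effect of the same swap on the core of compound 1 also remains open.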